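Swapping the Phenol for a Fluorine in the Styryl Ring

The compounds below may be only part of what the source reports. "The series", "measured", "known", "first", "only" and "open" are said of these compounds alone.

Going by the values given here, compound 2 `COc1ccc(/C=C(\C#N)C(=O)c2cc(OC)c(OC)c(OC)c2)cc1O` carries the only plain number in this set: in an ADME assay on K562 cells (Homo sapiens) for cytotoxicity, read by MTT assay, with a stated time of 5 days (on this read-out lower numbers stand for stronger inhibition and higher numbers for weaker inhibition), compound 2 gives 4200 nM. Compound 1 `COc1ccc(/C=C(\C#N)C(=O)c2cc(OC)c(OC)c(OC)c2)cc1O[Si](C)(C)C(C)(C)C`, its silyl-protected relative, reaches only the limit of the assay; in this assay compound 1 gives > 10000 nM, which is a limit and not a number. Among the compounds with values here, the one measured step, an at least 2.3-fold lower number from compound 1 to compound 2 (0.37 log units; beyond the scatter), shows that freeing the hydroxyl group strengthened inhibition at least modestly.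

Compound 3 `COc1ccc(/C=C(\C#N)C(=O)c2cc(OC)c(OC)c(OC)c2)c(F)c1` makes a different change: 2-fluoro-4-methoxyphenyl in place of 3-hydroxy-4-methoxyphenyl on a double-bonded chain carbon bound to a double-bonded chain carbon. The hydroxyl group that the measured step concerned is now gone altogether, and a fluorine enters instead. Within the data shown here, no measured step covers that swap, so the direction is uncertain; the loss of the hydroxyl that helped compound 2 suggests a weaker result is more likely than a stronger one.

For compound 3 in this assay the expected value is 8000 nM, within 2000 nM to 30000 nM, a step of a 1.9-fold higher number from compound 2 to compound 3 (0.28 log units; within the scatter).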

Compound 3, half-maximal inhibitory concentration: > 10000 nM
Compound 3: no number, only a limit (the forecaster's own chance of this, stated with the estimate: 35%); at least 1.2-fold (0.09 log units) between middle value and limit.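

With an at least 2.3-fold higher number from compound 2 to compound 3 (0.37 log units; beyond the scatter) in this assay, this change shows that the 3-hydroxy-4-methoxyphenyl of compound 2 cannot be exchanged for 2-fluoro-4-methoxyphenyl without losing inhibition. Going by these compounds alone, until now, the only comparison had capped the hydroxyl with a silyl group, whereas here the hydroxyl is absent and a fluorine enters under a different ring number, and both variations give a weaker result than compound 2. The true size of the loss cannot be read, and compound 1 and compound 3 cannot be ordered against each other, because both stop at the same point: the limit of > 10000 nM in this assay, at which 2 of the 3 values shown sit.

Still open, as far as these compounds go, is whether the loss comes from removing the hydroxyl or from adding the fluorine, since this single change does both at once. A plain hydrogen, an amine or a carboxylic acid in place of the hydroxyl would be needed to separate these possibilities.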